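Arylpiperazine-linked bicyclic imides at the alpha-1 receptor

The compounds below may be only part of what the source reports. "The series", "measured", "known", "first", "only" and "open" are said of these compounds alone.

Going by the values given here, two measured compounds form the series so far. Compound 1 `O=C1C2CCCN2C(=O)N1CN1CCN(c2ccccc2)CC1` and compound 2 `O=C1C2CCCCN2C(=O)N1CCCN1CCN(c2ccccc2)CC1` were tested in an assay on isolated protein for binding affinity to Adrenergic receptor alpha-1 (Rattus norvegicus), read by radioligand binding; on this read-out higher numbers stand for weaker inhibition and lower numbers for stronger inhibition. Compound 2 gives 11.4 nM, the lower of the two numbers; compound 1 gives 1000 nM, and the gap between them lies beyond the usual scatter. These two compounds differ in more than one place, so no single structural step can be read from the pair.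

Compound 3 `O=C1C2CCCCN2C(=O)N1CCCN1CCN(c2ccc([N+](=O)[O-])cc2)CC1` is not yet measured. Its difference from compound 2 is nitro in place of hydrogen on an aromatic carbon. Among the compounds with values here, no measured pair carries this change, so there is nothing to calibrate it against. The step of a 2.6-fold higher number from compound 2 to compound 3 (0.42 log units; beyond the scatter) is expected to be modest and toward a higher number, close to the edge of the scatter. Compound 3 is expected to give about 30 nM in this assay, with a range from 8 nM to 120 nM.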

Compound 3, inhibition constant: > 1000 nM
Compound 3 ended at the assay's limit; the forecaster's own chance of this, stated with the estimate: 2%; middle value at least 33-fold (1.52 log units) from the limit.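

Nitro in place of hydrogen on an aromatic carbon, para to a large group, gives an at least 87-fold higher number from compound 2 to compound 3 (1.94 log units; beyond the scatter) in this assay. Going by these compounds alone, this is the first change that can be read at a single place, and it shows that the aryl ring of compound 2 does not accept every substituent at this carbon without a large loss. Compound 3 reads > 1000 nM, which is a limit of the assay and not a number, so the step gives only a minimum size: the limit of > 1000 nM in this assay, at which 1 of the 3 values shown sits.

As far as these compounds go, whether an amine, a methoxy group or a chlorine at the same carbon stays near compound 2 remains open, as does nitro on another carbon of the ring. Compound 1 and compound 2 differ in more than one place, so the separate contributions of the core and the chain cannot be read, and a longer chain is also untested in the compounds shown.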